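Mirror-Image Side Chain on a Shared Core

This account rests on a few compounds, and the source may have more. Where it says the series, first, only, none or still open, it means among the compounds named here.

Compound 1 `O=C1c2c[n+]([O-])c3ccccc3c2C(=O)c2c1c1ccccc1n2Cc1cn(C[C@H](O)CO)nn1` is one of three compounds tested in a functional assay on HCT-116 cells (Homo sapiens) for cytotoxicity, read by MTT assay, with a stated time of 72 h; on this read-out lower numbers stand for stronger inhibition and higher numbers for weaker inhibition. Compound 1 gives 400 nM, the lowest of the three numbers shown, although its steps to the other two compounds lie within the scatter. Compound 2 `O=C1c2c[n+]([O-])c3ccccc3c2C(=O)c2c1c1ccccc1n2CCCCN1CCNCC1` gives 700 nM, and compound 3 `O=C1c2c[n+]([O-])c3ccccc3c2C(=O)c2c1c1ccccc1n2CCN1CCCCC1` gives 780 nM. The step of a 1.8-fold higher number from compound 1 to compound 2 (0.24 log units; within the scatter) and the step of a 2.0-fold higher number from compound 1 to compound 3 (0.29 log units; within the scatter) both stay within the scatter, as does a 1.1-fold higher number from compound 2 to compound 3 (0.05 log units; within the scatter); each of these changes exchanges a whole group on the chain attached to the aromatic nitrogen, yet none moves the read-out beyond the scatter.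

Going by the values given here, compound 4 `O=C1c2c[n+]([O-])c3ccccc3c2C(=O)c2c1c1ccccc1n2Cc1cn(C[C@@H](O)CO)nn1` has not yet been measured. the two compounds have the same atoms and bonds and differ only in configuration as drawn: 1 of 1 stereo elements differ; a stereocentre at a saturated chain carbon is drawn S in compound 1 and R in compound 4 No measured pair tests a change of this kind, since the measured steps replace entire groups rather than inverting one centre, and even those barely shift the number. For compound 4 the expected step is a 1.3-fold higher number from compound 1 to compound 4 (0.10 log units; within the scatter), with no movement beyond the scatter anticipated in either direction. Compound 4 is expected to give about 500 nM, within a range from 250 nM to 1000 nM.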

Compound 4, half-maximal inhibitory concentration: 190 nM
Beside the measured number, compound 4's estimate is 2.6-fold (0.42 log units) above it, and the stated range ends above it.
By their numbers in this assay, from the lowest: compound 4; then compounds 1, 2 and 3 (each within the scatter of the next).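

In this assay, inverting the one stereocentre in the side chain gives a 2.1-fold lower number from compound 1 to compound 4 (0.32 log units; beyond the scatter) and so moves the read-out beyond the scatter, which none of the whole-group exchanges among compounds 1, 2 and 3 did. With the centre drawn R, the 1-(2,3-dihydroxypropyl)-1H-1,2,3-triazol-4-yl group now stands apart from the piperidine and piperazine chains: a 4.1-fold lower number from compound 3 to compound 4 (0.61 log units; beyond the scatter) and a 3.7-fold lower number from compound 2 to compound 4 (0.57 log units; beyond the scatter) are both beyond the scatter, whereas the S form in compound 1 stayed within it. The lower number of compound 4 can be traced to that centre alone because of one fact: the fact that compounds 1 and 4 differ only in the configuration as drawn.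

Still open, on these data alone, is whether this preference survives with a methoxy group in place of either hydroxyl, or with a longer chain on the triazole. Whether it is particular to this side chain also remains unknown, as the compounds shown hold no other R and S pair.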